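Working notes: benzyl change from compound 2 to compound 3

A few compounds are considered here, and "the series" means these few. Any claim that something is new, unique, unknown or untested is made for them only; others in the source may bear on it.

In a functional assay, read by spectrophotometry, with a stated time of 30 min (on this read-out higher numbers stand for weaker inhibition and lower numbers for stronger inhibition), compound 1 `CC(C)(C)c1cc(CCC(=O)NC2CCN(Cc3ccccc3)CC2)cc(C(C)(C)C)c1O` gives 80300 nM and compound 2 `Cc1ccc(CN2CCC(CCNC(=O)/C=C/c3cc(C(C)(C)C)c(O)c(C(C)(C)C)c3)CC2)cc1` gives 60400 nM. These two values lie within the scatter of each other. Compound 3 `CC(C)(C)c1cc(/C=C/C(=O)NCCC2CCN(Cc3cccc(Cl)c3)CC2)cc(C(C)(C)C)c1O` differs from compound 2 by 3-chlorophenyl in place of 4-methylphenyl on a saturated chain carbon bound to an amine nitrogen in a ring; cut one bond further out, this reads 4-methylbenzyl to 3-chlorobenzyl. Going by the values given here, no measured pair shows this change, so the expectation rests on compound 2 at 60400 nM, and no step beyond the scatter is expected in this assay. The estimated step of a 1.1-fold lower number from compound 2 to compound 3 (0.04 log units; within the scatter) stays within the scatter. For compound 3 the expected value is 55000 nM, with an estimated range of 22000 nM to 120000 nM.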

Compound 3, half-maximal inhibitory concentration: 83100 nM
Compound 3: middle estimate off by 1.5-fold (0.18 log units), on the low side; measured number inside the range.
By their numbers in this assay, from the lowest: compounds 2, 1 and 3 (each within the scatter of the next).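

Going by these compounds alone, this is the first step read at this position: in this assay, 3-chlorophenyl in place of 4-methylphenyl on a saturated chain carbon bound to an amine nitrogen in a ring gives a 1.4-fold higher number from compound 2 to compound 3 (0.14 log units; within the scatter). Exchanging these two groups therefore moves the number no further than the scatter. No supporting measurement bears on this result.

Still open, going by these compounds, is whether a different kind of group here, such as a carboxylic acid or an amine in place of 3-chlorophenyl, would give a step beyond the scatter.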